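Swapping an Ester for Chlorine on a Shared Core

The source may hold more compounds than are shown below. What is called first, only, known or untested is meant among the compounds shown, and "the series" means these compounds.

Compound 1 `CC(C)OC(=O)c1ccc(NCc2cncn2Cc2ccc(-c3ccccc3)cc2)cc1-c1ccccc1` was tested in a toxicity assay on NIH3T3 cells (Mus musculus) for cytotoxicity, read by resazurin assay; a lower number here means that less compound is needed, a higher number that more compound is needed for the effect. For compound 1 only a limit of the assay is known, > 10000 nM, not a single number. In this assay compound 2 `COC(=O)c1ccc(NCc2cncn2Cc2ccccc2C#N)cc1-c1ccccc1` gives 25000 nM. In this assay compound 3 `COC(=O)c1ccc(NCc2cncn2Cc2cccc(-c3ccccc3)c2)cc1-c1ccccc1` has "not determined" (no result reported). On the numbers shown, compound 1 sits at the limit of > 10000 nM in this assay, at which 1 of the 3 values shown sits. Compound 4 `Clc1ccc(NCc2cncn2Cc2ccc(-c3ccccc3)cc2)cc1-c1ccccc1` differs from compound 1 in one place: chloro in place of isopropoxycarbonyl on an aromatic carbon. For the measured compounds named here, no measured pair shows this change, so its effect on the read-out is open. The step that the limit leaves unreadable from compound 1 to compound 4 is expected to stay within the usual scatter, in no particular direction. In this assay compound 4 is expected to give about 20000 nM, with a likely range from 8000 nM to 60000 nM.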

Compound 4, half-maximal effective concentration: > 1000 nM
Compound 4: no number, only a limit; the forecaster's own chance of this, stated with the estimate: 50%; the middle value lies beyond the limit too.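

No step can be read from compound 1 to compound 4: each of the two has only a limit, not a single number. The compounds shown leave open how far chloro in place of isopropoxycarbonyl shifts the read-out, or in which direction.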